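The source may hold more compounds than are shown below. What is called first, only, known or untested is meant among the compounds shown, and "the series" means these compounds.

In a functional assay on CHO cells for antagonist activity at adenosine receptor A2b (Homo sapiens) (a higher number here means a weaker inhibitor, a lower number a stronger inhibitor), compound 2 `CCOC(=O)c1nc(N)nc2nn(CC(C)(C)C)cc12` gives > 15000 nM, which is a limit of the assay rather than a measured number. Compound 1 `Cn1cc2c(C(N)=O)nc(N)nc2n1` gives > 20000 nM in this assay, also a limit. Compound 3 `CCOC(=O)c1nc(NC(=O)c2ccccc2)nc2nn(C(C)C)cc12` gives > 10000 nM in this assay, again a limit. Compound 2 therefore stands where the other two stand: none of the three values is a number, and for compound 2 the position is given by the limit of > 15000 nM in this assay, at which 1 of the 3 values shown sits. Compound 4 `CCOC(=O)c1nc(NC(=O)c2ccc(F)cc2)nc2nn(CC(C)(C)C)cc12` has not yet been tested. It differs from compound 2 in a single place: (4-fluorophenyl)carbonyl in place of hydrogen on a nitrogen on an aromatic ring. Going by the values given here, no step between two measured compounds is available here, so there is no measured change to set this one against; what can be said is that compound 3, which also carries an acyl group on that nitrogen, sits at a limit. The expectation for the step from compound 2 to compound 4 is therefore none beyond the usual scatter, with a step that the limit leaves unreadable from compound 2 to compound 4 as the estimated change, most likely ending again at a limit. For compound 4 the estimate in this assay is 20000 nM, within a range from 5000 nM to 80000 nM.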

Compound 4, inhibition constant: > 20000 nM
Compound 4 was reported as a limit; the forecaster's own chance of this, stated with the estimate: 80%; the middle value sits exactly at the limit.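

Compound 2 and compound 4 are both reported as limits in this assay, not as numbers, so the step between them cannot be read. All four compounds shown stand at limits, which leaves open which change to the shared core, if any, would give an actual measured number in this assay.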